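A few compounds are considered here, and "the series" means these few. Any claim that something is new, unique, unknown or untested is made for them only; others in the source may bear on it.

Measured so far:
compound 1, `c1ccc(-c2cn3ccnc3c(-c3ccc4ncn(C5CCCCC5)c4c3)n2)cc1`: 39.6%
compound 2, `COc1ccc(-c2cn3ccnc3c(-c3ccc4ncn(C5CCCCC5)c4c3)n2)cc1`: 69.6%
compound 3, `O=Cc1ccc(-c2cn3ccnc3c(-c3ccc4ncn(C5CCCCC5)c4c3)n2)cc1`: 46.9%

These values come from a functional assay on LOX IMVI cells (Homo sapiens) for inhibition, read by sulforhodamine B assay, with a stated time of 48 h, tested at 10 uM; on this read-out lower numbers stand for less inhibition and higher numbers for more inhibition at the one concentration tested (going by the name of the read-out). Compound 3 stands second highest of the three numbers. Its nearest neighbour is compound 1, the step being a number 7.3 percentage points higher from compound 1 to compound 3 (within the scatter); its furthest is compound 2, the step being a number 22.7 percentage points lower from compound 2 to compound 3 (beyond the scatter). The remaining step is a number 30 percentage points higher from compound 1 to compound 2 (beyond the scatter).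

Compound 4, `c1cn2cc(-c3ccsc3)nc(-c3ccc4ncn(C5CCCCC5)c4c3)c2n1`, differs from compound 3 in one place: thiophen-3-yl in place of 4-formylphenyl on an aromatic carbon. The measured steps that touch this position are the introduction of formyl, a number 7.3 percentage points higher from compound 1 to compound 3 (within the scatter), which stayed within the scatter, and the exchange of methoxy for formyl, a number 22.7 percentage points lower from compound 2 to compound 3 (beyond the scatter). Going by the values given here, the exchange of the whole aromatic ring for thiophen-3-yl has no measured counterpart, so the expectation rests on compounds 1 and 3 alone. No step beyond the scatter is expected in this assay , the expected step being a number 4.9 percentage points lower from compound 3 to compound 4 (within the scatter). Compound 4 is estimated at 42%, within a range of 20% to 65%.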

Compound 4, a percentage reported as inhibition, at one concentration (the size of the read-out at that concentration, not a potency): 4.9%
For compound 4 the middle estimate is 37.1 percentage points above the measured one; the whole stated range lies above it.
By their numbers in this assay, from the lowest: compound 4; then compounds 1 and 3 (each within the scatter of the next); then compound 2.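

In this assay, replacing the six-membered aromatic ring with thiophen-3-yl lowers the number against all three earlier compounds: a number 42 percentage points lower from compound 3 to compound 4 (beyond the scatter), a number 64.7 percentage points lower from compound 2 to compound 4 (beyond the scatter) and a number 34.7 percentage points lower from compound 1 to compound 4 (beyond the scatter). The earlier compounds shown here varied only a substituent on the phenyl ring, giving modest steps or none beyond the scatter, whereas exchanging the ring itself gives large steps, and compound 4 stands lowest of the four. Nothing at hand accounts for this loss.

The compounds shown do not separate the effect of the ring size from that of the sulfur atom, since only one five-membered ring appears. Open as well is how thiophen-2-yl, a furan ring, or a phenyl ring carrying an amine or a carboxylic acid would read in this assay.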